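The compounds below may be only part of what the source reports. "The series", "measured", "known", "first", "only" and "open" are said of these compounds alone.

Compound 1 `CNc1cc(=O)n(Cc2cc(C)cc(C)c2)c(=O)n1Cc1ccccc1` is one of three compounds examined in an ADME assay on MT4 cells (Homo sapiens) for cytotoxicity, read by MTT assay, with a stated time of 4 days; on this read-out lower numbers stand for higher toxicity in this test and higher numbers for lower toxicity in this test. Compound 1 gives 65000 nM, and compound 3 `Cc1cc(C)cc(Cn2c(=O)cc(N=[N+]=[N-])n(CC#N)c2=O)c1` gives 60000 nM, the two numbers lying within the usual scatter of each other, so neither can be set above the other. For compound 2 `Cc1cc(C)cc(Cn2c(=O)cc(N)n(Cc3ccncc3)c2=O)c1` only a limit is recorded, > 100000 nM, and the note on that reading is the limit of > 100000 nM in this assay, at which 1 of the 3 values shown sits. Compound 4 `Cc1cc(C)cc(Cn2c(=O)cc(NCc3ccccc3)n(Cc3ccccc3)c2=O)c1` has not yet been measured. It differs from compound 1 by phenyl in place of hydrogen on a saturated chain carbon bound to a nitrogen on an aromatic ring. Among the measured compounds shown here, no step between measured compounds shows this change, so the expectation rests on compound 1 alone: a step from compound 1 to compound 4 of a 2.2-fold lower number from compound 1 to compound 4 (0.34 log units; beyond the scatter) toward a lower number is expected. Compound 4 is accordingly estimated at 30000 nM, between 10000 nM and 90000 nM.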

Compound 4, half-maximal cytotoxic concentration: > 100000 nM
Compound 4 ended at the assay's limit; the forecaster's own chance of this, stated with the estimate: 10%; at least 3.3-fold (0.52 log units) between middle value and limit.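

In this assay, the change from methylamino to benzylamino gives an at least 1.5-fold higher number from compound 1 to compound 4 (0.18 log units; that floor lies within the scatter), so phenyl on this saturated chain carbon brings no lower number, and this position tolerates the larger group in this test. Compound 4 reads as a limit and not as a number: the limit of > 100000 nM in this assay, at which 2 of the 4 values shown sit.

As far as these compounds go, the true size of the step therefore stays unknown, and its floor alone does not establish a rise. Also open, from the compounds shown here alone, is how this position would respond to a carboxylic acid, an amine or a longer chain on the same carbon.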